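Notes on a pyrimidinone series: amide variation at the side chain

This account rests on a few compounds, and the source may have more. Where it says the series, first, only, none or still open, it means among the compounds named here.

Measured compounds:
- compound 1, `CCCCc1nc(C)c(CCC(=O)OCC)c(=O)n1Cc1ccc(-c2ccccc2-c2nnn[nH]2)cc1`, 0.066 mg/kg
- compound 2, `CCCCc1nc(C)c(CC(=O)N2CCC[C@H]2C(=O)OC)c(=O)n1Cc1ccc(-c2ccccc2-c2nnn[nH]2)cc1`, 0.043 mg/kg
- compound 3, `CCCCc1nc(C)c(CC(=O)N2CCC[C@H]2C(N)=O)c(=O)n1Cc1ccc(-c2ccccc2-c2nnn[nH]2)cc1`, 0.023 mg/kg

All three values come from an in vivo functional assay on the whole organism for inhibition, with Rattus norvegicus as the target; a lower number here means that less compound is needed, a higher number that more compound is needed for the effect. Compound 3 has the lowest of the three numbers; its gap to compound 2 is within the scatter, while compound 1 sits further off, the step of a 2.9-fold lower number from compound 1 to compound 3 (0.46 log units; beyond the scatter) being the only one of the three that goes beyond the scatter. Among the measured compounds shown here, the step of a 1.5-fold lower number from compound 1 to compound 2 (0.19 log units; within the scatter) and the step of a 1.9-fold lower number from compound 2 to compound 3 (0.27 log units; within the scatter) both stay within the scatter, so the series so far shows a shallow profile with only the end points separated.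

Compound 4, `CCCCc1nc(C)c(CCC(=O)N2CCCCC2)c(=O)n1Cc1ccc(-c2ccccc2-c2nnn[nH]2)cc1`, has not yet been run in this assay. Its change from compound 3 is ((piperidin-1-yl)carbonyl)methyl in place of (2-carbamoylpyrrolidin-1-yl)carbonyl on a saturated chain carbon bound to an aromatic carbon. For the measured compounds named here, the closest precedent is compound 1, which carries a two-carbon chain to an ester rather than a ring amide and gives a number higher than compound 3 by the step of a 2.9-fold lower number from compound 1 to compound 3 (0.46 log units; beyond the scatter). Nothing measured covers the piperidine amide itself, so the expectation leans on compound 1 and compound 2 as the nearest analogues and on the loss of the donor counted above.

Compound 4 is therefore expected to come out near 0.05 mg/kg in this assay, within 0.02 mg/kg to 0.13 mg/kg, which means an estimated step of a 2.2-fold higher number from compound 3 to compound 4 (0.34 log units; beyond the scatter), most likely not beyond the scatter.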

Compound 4, dose for half-maximal effect: 0.164 mg/kg
The estimate for compound 4 lay 3.3-fold (0.52 log units) below the measured number, and the stated range ends below it.
By their numbers in this assay, from the lowest: compounds 3, 2 and 1 (each within the scatter of the next, the first and the last beyond it); then compound 4.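

In this assay a ring amide alone does not bring the number down: piperidin-1-yl in place of ethoxy on a carbonyl carbon goes the other way (a 2.5-fold higher number from compound 1 to compound 4 (0.40 log units; beyond the scatter)), so this position does not simply favour an amide over an ester. Among the compounds shown here, the gap is wider against the two pyrrolidine amides (a 3.8-fold higher number from compound 2 to compound 4 (0.58 log units; beyond the scatter)) and wider again against the carbamoyl compound (a 7.1-fold higher number from compound 3 to compound 4 (0.85 log units; beyond the scatter)), which makes compound 4 the only compound whose steps to all the others are beyond the scatter and shows that the series is less flat at this position than the first three compounds suggested. No measured data here explain why the number rises at this position.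

The step from compound 3 to compound 4 changes several things at once, namely the ring size, the chain from ((2-carbamoylpyrrolidin-1-yl)carbonyl)methyl to 2-((piperidin-1-yl)carbonyl)ethyl, and the loss of the carbamoyl group, and the compounds shown cannot separate these. Still open, as far as these compounds go, are how an unsubstituted pyrrolidin-1-yl amide or a morpholin-4-yl amide would read on either chain, and how a free carboxylic acid would read on the pyrrolidine ring in place of the methyl ester or the carbamoyl group.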